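Triazole analogues of a trimethoxyphenyl scaffold against leukaemia cells

The source may report more compounds than this note shows. Statements on the series, on what has been measured and on what is new or still open speak of the compounds shown alone.

The measured compounds and their values:
compound 1 `COc1cc(-c2ncnn2-c2cccc(N)c2)cc(OC)c1OC`: > 10000 nM
compound 2 `CCOc1ccc(-c2ncnn2-c2cc(OC)c(OC)c(OC)c2)cc1Cl`: 20 nM
compound 3 `CCOc1ccc(-c2ncnn2-c2cc(OC)c(OC)c(OC)c2)cc1`: 20 nM

The read-out throughout is a functional assay on K562 cells (Homo sapiens) for antiproliferative activity, read by MTT assay, with a stated time of 72 h; a lower number here means a stronger inhibitor, a higher number a weaker inhibitor. Compound 1 gives only a limit of the assay, > 10000 nM, and so no number for it is known. In this assay, going by the values given here, compound 2 gives 20 nM and compound 3 gives 20 nM; the one step among the measured compounds, no change at the digits printed from compound 2 to compound 3 (within the scatter), lies within the scatter, so removing chloro from an aromatic carbon changed nothing there.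

The step under study leads from compound 1 to compound 4 `COc1cc(-c2ncnn2-c2ccc(Cl)cc2)cc(OC)c1OC`. The change is 4-chlorophenyl in place of 3-aminophenyl on an aromatic nitrogen. Among the compounds with values here, no measured step matches it: the step from compound 2 to compound 3 concerns chloro on a different ring of a compound with the opposite arrangement of the two aryl groups, and compound 1 itself sits at the limit (the limit of > 10000 nM in this assay, at which 1 of the 3 values shown sits). The direction of this assay for compound 4 is therefore uncertain; at best a modest gain is expected.

Compound 4 is estimated at 5000 nM, with a range from 500 nM to 30000 nM. The expected step is an at least 2.0-fold lower number from compound 1 to compound 4 (0.30 log units; that floor lies within the scatter).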

Compound 4, half-maximal inhibitory concentration: > 10000 nM
Compound 4: a limit, no number; the forecaster's own chance of this, stated with the estimate: 50%; at least 2.0-fold (0.30 log units) between middle value and limit.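

In this assay compound 4 gives > 10000 nM, which is a limit of the assay and not a number. Going by these compounds alone, compound 1 also stands at a limit, so no step between compound 1 and compound 4 can be read: the limit of > 10000 nM in this assay, at which 2 of the 4 values shown sit. The compounds shown leave open whether 4-chlorophenyl in place of 3-aminophenyl on the aromatic nitrogen changes the read-out at all.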